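The compounds below may be only part of what the source reports. "The series", "measured", "known", "first", "only" and "open" are said of these compounds alone.

Series notes. Compound 1 `CCOC(=O)c1c(-c2cccc(-c3ccccc3)c2)[nH]c2cc(OC(C)C)ccc2c1=O` carries a phenyl on a six-membered aromatic ring of carbon only; compound 2 `CCOC(=O)c1c(-c2cccc(OC)c2)[nH]c2cc(OC(C)C)ccc2c1=O` carries a methoxy at that place instead. Compound 3 `CCOC(=O)c1c(-c2cccc(-c3ccccc3)c2)[nH]c2cc(Cl)c(OC)cc2c1=O` keeps the phenyl on the core of compound 3, and compound 4 `CCOC(=O)c1c(-c2cccc(OC)c2)[nH]c2cc(Cl)c(OC)cc2c1=O` is its methoxy counterpart, not yet measured. In an ADME assay on Raji cells (Homo sapiens) for cytotoxicity, read by luminescence, with a stated time of 72 h (on this read-out lower numbers stand for an effect already at smaller amounts and higher numbers for an effect only at larger amounts of compound), compound 1 gives > 21500 nM, which is a limit of the assay and not a number. In this assay compound 2 gives > 21500 nM, again a limit rather than a number. In this assay compound 3 gives > 21500 nM, also a limit rather than a number. The step that the two limits leave unreadable from compound 1 to compound 2 therefore cannot be sized, since both of its ends sit at the limit of > 21500 nM in this assay, at which 3 of the 3 values shown sit. The change behind that step is methoxy in place of phenyl on an aromatic carbon. How the core of compound 3 differs from the core of compound 1 is not broken down here. The change from compound 3 to compound 4 is the same kind of change, (methoxy in place of phenyl on an aromatic carbon), and its place is described in the same words. Across the three measured compounds every value rests at the limit of > 21500 nM in this assay, at which 3 of the 3 values shown sit, so nothing in this assay yet reads as a number. Compound 4 is expected to follow suit: the step that the limit leaves unreadable from compound 3 to compound 4 is expected to be unreadable in the same way because compound 3 sits at the limit of > 21500 nM in this assay, at which 3 of the 3 values shown sit. Compound 4 is thus estimated at 30000 nM, most likely reported only as a limit again, with a range from 10000 nM to 100000 nM.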

Compound 4, half-maximal effective concentration: > 21500 nM
Compound 4: a limit, no number; the forecaster's own chance of this, stated with the estimate: 85%; the middle value is on the limit's open side.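

No new step can be read: compound 3 and compound 4 both give a limit and not a number in this assay, so the step between them stays unreadable, as does the one between compound 1 and compound 2: the limit of > 21500 nM in this assay, at which 4 of the 4 values shown sit.

The compounds shown leave open how large the effect of methoxy in place of phenyl is on either core, and whether any compound of the series gives a number in this assay at all.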